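Amide replaced by ester on the shared core

The compounds below may be only part of what the source reports. "The series", "measured", "known", "first", "only" and "open" are said of these compounds alone.

compound 1 `COc1ccc(OC)c(-c2cn(-c3ccc(O)c(C(=O)Nc4cccc(C(F)(F)F)c4)c3)nn2)c1`: 46%
compound 2 `COc1ccccc1-c1cn(-c2ccc(O)c(C(=O)Nc3cccc(C(F)(F)F)c3)c2)nn1`: 61%
compound 3 `COc1ccc(-c2cn(-c3ccc(O)c(C(=O)Nc4cccc(C(F)(F)F)c4)c3)nn2)cc1`: 9%

In a functional assay on HCT-116 cells (Homo sapiens) for inhibition, read by MTT assay, with a stated time of 2 days, tested at 10 uM (a higher number here means more inhibition at the concentration tested (going by the name of the read-out), a lower number less inhibition), compound 2 stands highest of the three numbers, with compound 1 nearest and compound 3 furthest. The step of a number 15 percentage points higher from compound 1 to compound 2 (beyond the scatter) is modest, whereas a number 52 percentage points lower from compound 2 to compound 3 (beyond the scatter) and a number 37 percentage points lower from compound 1 to compound 3 (beyond the scatter) are both large. All three measured steps concern only the methoxyphenyl group; none touches the carbonyl carbon.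

Compound 4 `COc1ccccc1-c1cn(-c2ccc(O)c(C(=O)OCCCc3ccccc3)c2)nn1` differs from compound 2 at exactly that untouched site: 3-phenylpropoxy in place of (3-(trifluoromethyl)phenyl)amino on a carbonyl carbon. Among the compounds with values here, no measured step bears on this change, so nothing in the set tells how large a step to expect or in which direction, and the expectation for compound 4 rests on compound 2 alone, which gives 61% in this assay. The expected step is therefore a number 11 percentage points lower from compound 2 to compound 4 (beyond the scatter), with a wide range around it. Compound 4 is estimated at 50%, between 15% and 75%.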

Compound 4, a percentage reported as inhibition, at one concentration (the size of the read-out at that concentration, not a potency): 7%
Compound 4: middle estimate off by 43 percentage points, on the high side; measured number outside the range, below it.
By their numbers in this assay, from the lowest: compounds 4 and 3 (each within the scatter of the next); then compound 1; then compound 2.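

Within the data shown here, on the carbonyl carbon, 3-phenylpropoxy in place of (3-(trifluoromethyl)phenyl)amino gives a number 54 percentage points lower from compound 2 to compound 4 (beyond the scatter) in this assay, so this site, untouched by the earlier steps, also carries a large step. With the 2-methoxyphenyl group held fixed, the inhibition seen with the amide does not carry over to this ester, even though both groups bring one six-membered aromatic ring of carbon only. Nothing available gives a cause for this step.

The step changes the amide hydrogen, the linking atom, the chain and the trifluoromethyl group together, so the compounds shown do not tell which of these accounts for it. A 3-phenylpropyl amide or a 3-(trifluoromethyl)phenyl ester would separate linker from substituent, and a carboxylic acid on the same carbonyl carbon remains an open comparison.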